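Aryl variation on the shared core: antiproliferative read-out

This account rests on a few compounds, and the source may have more. Where it says the series, first, only, none or still open, it means among the compounds named here.

Measured compounds:
compound 1, `CCC1=C(O)c2c(oc(-c3ccc(CBr)cc3)cc2=O)C(CC)(CC)C1=O`, 27.9 uM
compound 2, `CCC1=C(O)c2c(oc(-c3ccccc3OC)cc2=O)C(CC)(CC)C1=O`, 3.26 uM

In a functional assay on KBVIN cells (Homo sapiens) for antiproliferative activity, read by sulforhodamine B assay, with a stated time of 3 days (on this read-out higher numbers stand for an effect only at larger amounts of compound and lower numbers for an effect already at smaller amounts), compound 2 holds the lowest of the two numbers, with compound 1 standing at an 8.6-fold lower number from compound 1 to compound 2 (0.93 log units; beyond the scatter) from it. Compound 3 is `CCC1=C(O)c2c(oc(-c3cc(C)ccc3F)cc2=O)C(CC)(CC)C1=O`; it differs from compound 2 by 2-fluoro-5-methylphenyl in place of 2-methoxyphenyl on an aromatic carbon. Going by the values given here, the only measured step, from compound 1 to compound 2, concerns a different pair of aryl groups, so nothing measured bears directly on this change, and no step beyond the scatter is expected for this assay. Compound 3 is estimated at 5 uM (1.5 uM to 16 uM), which means an expected 1.5-fold higher number from compound 2 to compound 3 (0.19 log units; within the scatter).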

Compound 3, concentration for half-maximal effect: 3.24 uM
For compound 3 the middle estimate is 1.5-fold (0.19 log units) above the measured one; the range from low to high includes it.
By their numbers in this assay, from the lowest: compounds 3 and 2 (each within the scatter of the next); then compound 1.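

In this assay the change to 2-fluoro-5-methylphenyl on the aromatic carbon next to the ring oxygen reads as a 1.0-fold lower number from compound 2 to compound 3 (0.00 log units; within the scatter) and so the number here does not depend on the oxygen of 2-methoxyphenyl. With an 8.6-fold lower number from compound 1 to compound 3 (0.94 log units; beyond the scatter) as a second change beyond the scatter, the gap to 4-(bromomethyl)phenyl no longer rests on 2-methoxyphenyl alone. Nothing available explains either step.

Going by these compounds, whether an aryl group carrying an amine or a carboxylic acid keeps this number remains open. The separate contributions of the fluoro and methyl groups also stay unresolved.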